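The source may hold more compounds than are shown below. What is called first, only, known or untested is meant among the compounds shown, and "the series" means these compounds.

Measured in a functional assay on HT-29 cells (Homo sapiens) for cytotoxicity, read by neutral red uptake, with a stated time of 72 h; a lower number here means a stronger inhibitor, a higher number a weaker inhibitor:
compound 1 `CCCCNc1nc(SCC)nc2ncccc12` gives 25300 nM
compound 2 `CCCCCNc1nc(SCC)nc2ncccc12` gives 5100 nM
compound 3 `CCCCCCCNc1nc(SCC)nc2ncccc12` gives 19900 nM

Compound 1 stands at the highest number of the three; the nearest step is a 1.3-fold lower number from compound 1 to compound 3 (0.10 log units; within the scatter), within the scatter, the widest is a 5.0-fold lower number from compound 1 to compound 2 (0.70 log units; beyond the scatter). Compound 4 `CCCCNc1nc(SC(C)C)nc2ncccc12` differs from compound 1 by methyl in place of hydrogen on a saturated chain carbon bound to a saturated chain carbon and a sulfur. Among the compounds with values here, none of the measured steps bears on this place: a 5.0-fold lower number from compound 1 to compound 2 (0.70 log units; beyond the scatter), a 3.9-fold higher number from compound 2 to compound 3 (0.59 log units; beyond the scatter) and the step to compound 3 all alter the chain carried by the nitrogen on the aromatic ring, not the ethylsulfanyl side. No direction can be drawn from them, so the step expected in this assay is a 1.3-fold lower number from compound 1 to compound 4 (0.10 log units; within the scatter), within the scatter. Compound 4 is estimated at 20000 nM, with a range from 6000 nM to 60000 nM.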

Compound 4, half-maximal inhibitory concentration: 32100 nM
For compound 4 the middle estimate is 1.6-fold (0.21 log units) below the measured one, and the stated range covers the measured number.
By their numbers in this assay, from the lowest: compound 2; then compounds 3, 1 and 4 (each within the scatter of the next).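

Ethylsulfanyl to isopropylsulfanyl is the first change shown on the sulfur side of the series, and in this assay it gives a 1.3-fold higher number from compound 1 to compound 4 (0.10 log units; within the scatter) and so stays within the scatter. The added methyl therefore does not separate compound 4 from compound 1, whereas the methyl added on the nitrogen chain gives a 5.0-fold lower number from compound 1 to compound 2 (0.70 log units; beyond the scatter) and lies beyond it. Nothing available explains this result.

Still open, going by these compounds, is whether a longer chain, a phenyl ring or an amine on the sulfur would shift the number. Also open, on these data alone, is whether isopropylsulfanyl would behave the same way on compound 2.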